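The source may hold more compounds than are shown below. What is called first, only, known or untested is meant among the compounds shown, and "the series" means these compounds.

Measured compounds:
- compound 1, `O=Cc1ccc(-c2cn3ccnc3c(-c3ccc4ncn(C5CCCCC5)c4c3)n2)cc1`, 14.4%
- compound 2, `c1ccc2c(-c3cn4ccnc4c(-c4ccc5ncn(C6CCCCC6)c5c4)n3)cccc2c1`, 9.08%
- compound 3, `c1cn2cc(-c3ccsc3)nc(-c3ccc4ncn(C5CCCCC5)c4c3)c2n1`, 0.39%

All three share one core and differ only in the aromatic group attached to it. In a functional assay on SNB-19 cells (Homo sapiens) for inhibition, read by sulforhodamine B assay, with a stated time of 48 h, tested at 10 uM (on this read-out lower numbers stand for less inhibition and higher numbers for more inhibition at the one concentration tested (going by the name of the read-out)), compound 3 gives the lowest of the three numbers, 0.39%. Its nearest neighbour is compound 2, with a number 8.7 percentage points lower from compound 2 to compound 3 (within the scatter), so these two cannot be told apart. Compound 1 stands further off: a number 14 percentage points lower from compound 1 to compound 3 (beyond the scatter), a modest but real gap. The step of a number 5.3 percentage points lower from compound 1 to compound 2 (within the scatter) likewise stays inside the scatter.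

Compound 4, `Fc1ccccc1-c1cn2ccnc2c(-c2ccc3ncn(C4CCCCC4)c3c2)n1`, is the next step from compound 3. The change is 2-fluorophenyl in place of thiophen-3-yl on an aromatic carbon. For the measured compounds named here, two measured steps bear on it, as both end at the thiophen-3-yl compound: the step from a six-membered ring of carbon only in compound 2 and from 4-formylphenyl in compound 1. Reversing that direction, toward a ring of carbon only, the expected movement is a small rise in this assay, of roughly the size seen between compound 2 and compound 3, which may or may not clear the scatter. Compound 4 is therefore estimated at 8%, with a likely range from 0% to 25%, meaning an expected step of a number 7.6 percentage points higher from compound 3 to compound 4 (within the scatter).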

Compound 4, a percentage reported as inhibition, at one concentration (the size of the read-out at that concentration, not a potency): 7.56%
Compound 4: the middle estimate sits 0.4 percentage points above what was measured; measured number inside the range.
By their numbers in this assay, from the lowest: compounds 3, 4, 2 and 1 (each within the scatter of the next, the first and the last beyond it).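

In this assay, 2-fluorophenyl on this aromatic carbon, next to the ring nitrogen, cannot be told apart from any of the three earlier groups: thiophen-3-yl (a number 7.2 percentage points higher from compound 3 to compound 4 (within the scatter)), naphthalen-1-yl (a number 1.5 percentage points lower from compound 2 to compound 4 (within the scatter)) and 4-formylphenyl (a number 6.8 percentage points lower from compound 1 to compound 4 (within the scatter)). For the compounds shown here, the earlier compounds held one gap beyond the scatter, the one separating compound 1 from compound 3, and compound 4 now lies within the scatter of both, so this single swap gives no readable change from any neighbour. No measurement on hand offers an explanation for how these aromatic groups compare at this position.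

The compounds shown leave open whether a group of a different kind at this place, such as a primary amine, a carboxylic acid on the phenyl ring or a longer alkyl chain, would move the number clearly away from this cluster. They also leave open how compound 4 would behave at other concentrations, since a single-concentration percentage is not a potency.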